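Replacing butoxycarbonyl in compound 2

A few compounds are considered here, and "the series" means these few. Any claim that something is new, unique, unknown or untested is made for them only; others in the source may bear on it.

Values in a functional assay on HEL 299 cells (Homo sapiens); on this read-out higher numbers stand for weaker inhibition and lower numbers for stronger inhibition:
Compound 1 `NC(=O)c1nn([C@@H]2O[C@H](CO)[C@@H](O)[C@H]2O)cc1I`: > 300000 nM, a limit of the assay
Compound 2 `CCCCOC(=O)c1nn([C@@H]2O[C@H](CO)[C@@H](O)[C@H]2O)cc1I`: 40000 nM
Compound 3 `Cc1noc(-c2nn([C@@H]3O[C@H](CO)[C@@H](O)[C@H]3O)cc2I)n1`: not yet measured

Among the measured compounds shown here, compound 2 holds the only actual number in this assay so far, the other value being a limit. The change under consideration is 3-methyl-1,2,4-oxadiazol-5-yl in place of butoxycarbonyl on an aromatic carbon, with 3-methyl-1,2,4-oxadiazol-5-yl in place of butoxycarbonyl on an aromatic carbon. For the measured compounds named here, one measured step bears on it: an at least 7.5-fold lower number from compound 1 to compound 2 (0.87 log units; beyond the scatter), with butoxy in place of amino on a carbonyl carbon. Going by the values given here, that step shows that a change in this group can move the read-out beyond the scatter, but no measured compound carries the incoming group. Compound 3 loses the butoxy that accompanied the lower number in that step, so a modest move towards weaker inhibition is expected, with wide uncertainty. The expected step is a 2.0-fold higher number from compound 2 to compound 3 (0.30 log units; within the scatter). For compound 3 the estimate is 80000 nM, with an expected range of 20000 nM to 300000 nM.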

Compound 3, half-maximal inhibitory concentration: 7900 nM
Compound 3: the middle estimate sits 10-fold (1.01 log units) above what was measured; the measured number lies below the stated range.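

In this assay, a lower number at this aromatic carbon does not depend on the ester or its butoxy chain: 3-methyl-1,2,4-oxadiazol-5-yl in place of butoxycarbonyl gives a 5.1-fold lower number from compound 2 to compound 3 (0.70 log units; beyond the scatter). Against carbamoyl, the same group gives an at least 37-fold lower number from compound 1 to compound 3 (1.57 log units; beyond the scatter), so compound 3 shows the strongest inhibition of the three groups compared at this position. The value of compound 1 is a limit and not a number, so that last step has a floor but no exact size: the limit of > 300000 nM in this assay, at which 1 of the 3 values shown sits.

Going by these compounds, it remains open whether the ring itself or its methyl group accounts for the lower number, and whether a phenyl group in place of that methyl would go further. On these data alone, how a carboxylic acid or an amine at this carbon would compare also remains open.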